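The source may report more compounds than this note shows. Statements on the series, on what has been measured and on what is new or still open speak of the compounds shown alone.

Compound 1 `Cc1nnc(SCC(=O)N/N=c2/scc(-c3ccc(F)cc3)n2-c2ccccc2)s1`: in a functional assay on C6 cells (Rattus norvegicus) for cytotoxicity, read by MTT assay, with a stated time of 24 h, tested at 200 ug/mL (on this read-out lower numbers stand for a stronger effect and higher numbers for a weaker effect at the one concentration tested), compound 1 gives 26.5%.
Compound 2 `O=C(CSc1nnnn1-c1ccccc1)N/N=c1/scc(-c2ccc(F)cc2)n1-c1ccccc1`: compound 2 gives 30.6%.

Compound 2 gives the higher of these two numbers, yet the step of a number 4.1 percentage points higher from compound 1 to compound 2 (within the scatter) is within the scatter, so the two cannot be told apart. Compound 3 `N#Cc1ccc(-c2cs/c(=N/NC(=O)CSc3nnnn3-c3ccccc3)n2-c2ccccc2)cc1` differs from compound 2 by cyano in place of fluoro on an aromatic carbon. Among the measured compounds shown here, the one measured step exchanged a group on a sulfur, a different place, so no measured step bears on this change, and nothing beyond the scatter is expected: the expected step is a number 0.6 percentage points lower from compound 2 to compound 3 (within the scatter). Compound 3 is therefore estimated at 30%, with a range from 15% to 50%.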

Compound 3, a percentage reported as activity, at one concentration (the size of the read-out at that concentration, not a potency): 54%
The estimate for compound 3 lay 24 percentage points below the measured number; measured number outside the range, above it.
By their numbers in this assay, from the lowest: compounds 1 and 2 (each within the scatter of the next); then compound 3.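

Exchanging 4-fluorophenyl for 4-cyanophenyl gives a number 23.4 percentage points higher from compound 2 to compound 3 (beyond the scatter) in this assay, which means a weaker effect at the one concentration tested. The substituent on this aromatic carbon therefore matters for the read-out, something the earlier exchange on the sulfur did not reveal. No measurement here explains this difference.

With only fluoro and cyano shown at this place, it remains open how an amine or a methoxy group would read. As far as these compounds go, it also remains open whether cyano would give a similar step alongside the 5-methyl-1,3,4-thiadiazol-2-yl group on the sulfur.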